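The source may hold more compounds than are shown below. What is called first, only, known or untested is meant among the compounds shown, and "the series" means these compounds.

In a functional assay on NB-4 cells (Homo sapiens) for cytotoxicity, read by CCK-8 assay, with a stated time of 24 h (a higher number here means a weaker inhibitor, a lower number a stronger inhibitor), compound 2 `C=CC(=O)N1C(=O)CC(c2ccc(-c3ccccc3)cc2)Sc2ccccc21` gives 57700 nM. It stands among three numbers that all lie within the usual scatter of one another: compound 1 `C=CC(=O)N1C(=O)CC(c2ccc([N+](=O)[O-])cc2)Sc2ccccc21` gives 37700 nM, and compound 3 `C=CC(=O)N1C(=O)CC(c2ccc(Br)cc2)Sc2ccccc21` gives 59400 nM. All three share one core and differ only in a single group on an aromatic carbon, and every swap of that group stayed small: a 1.5-fold higher number from compound 1 to compound 2 (0.18 log units; within the scatter), a 1.6-fold higher number from compound 1 to compound 3 (0.20 log units; within the scatter) and a 1.0-fold higher number from compound 2 to compound 3 (0.01 log units; within the scatter). Compound 4 `C=CC(=O)N1C(=O)CC(c2ccc(C#N)cc2)Sc2ccccc21` differs from compound 2 in the same way, by cyano in place of phenyl on an aromatic carbon. Since each earlier swap at this position left the number within the scatter, the expected step is a 1.2-fold lower number from compound 2 to compound 4 (0.06 log units; within the scatter), with no change beyond the scatter. Compound 4 is therefore estimated at 50000 nM, with a range from 25000 nM to 100000 nM.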

Compound 4, half-maximal inhibitory concentration: 62400 nM
For compound 4 the middle estimate is 1.2-fold (0.10 log units) below the measured one, within the range that was stated.
By their numbers in this assay, from the lowest: compounds 1, 2, 3 and 4 (each within the scatter of the next).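

Cyano has far fewer heavy atoms than phenyl and no ring, yet in this assay it also stays within the scatter of every group before it. Against phenyl the step is (a 1.1-fold higher number from compound 2 to compound 4 (0.03 log units; within the scatter)), against bromo (a 1.1-fold higher number from compound 3 to compound 4 (0.02 log units; within the scatter)) and against nitro (a 1.7-fold higher number from compound 1 to compound 4 (0.22 log units; within the scatter)). At this position, then, a group with a ring and one without give numbers that cannot be told apart. Going by these compounds, whether an amine, a carboxylic acid or a longer chain here would also stay within the scatter remains open. Nothing shown gives a reason for this flat result.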